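This account rests on a few compounds, and the source may have more. Where it says the series, first, only, none or still open, it means among the compounds named here.

Measured compounds:
- compound 1, `CC(C)CCOc1ccccc1C1CC(=O)c2ccccc2O1`: 43.6%
- compound 2, `CCCOc1ccccc1C1CC(=O)c2ccccc2O1`: 43.6%
- compound 3, `C=CCOc1ccccc1C1CC(=O)c2ccccc2O1`: 47%

All three numbers come from a functional assay on J774.A1 cells (Mus musculus) for inhibition, read by immunoassay, with a stated time of 12 h, tested at 30 uM; on this read-out higher numbers stand for more inhibition at the one concentration tested (going by the name of the read-out) and lower numbers for less inhibition. Compound 3 gives the highest number of the three, but its nearest neighbour in value is compound 1 and the step of a number 3.4 percentage points higher from compound 1 to compound 3 (within the scatter), like the step of a number 3.4 percentage points higher from compound 2 to compound 3 (within the scatter), lies within the scatter, so no order among compounds 1, 2 and 3 can be read from this assay. The step of no change at the digits printed from compound 1 to compound 2 (within the scatter) likewise shows nothing.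

Compound 4, `CC(C)=CCOc1ccccc1C1CC(=O)c2ccccc2O1`, has not yet been measured. It differs from compound 3 by 2-methylprop-1-en-1-yl in place of vinyl on a saturated chain carbon bound to an oxygen on an aromatic ring. For the measured compounds named here, the steps that bear on it are those that alter the chain on the oxygen on the aromatic ring: from ethyl or isobutyl to vinyl, each within the scatter, and from isopropyl to methyl further along the chain, also within the scatter. Three changes of chain size and branching at this position have left the number unmoved, so no step beyond the scatter is expected in this assay for compound 4, and the estimated step is a number 2 percentage points lower from compound 3 to compound 4 (within the scatter). The expected value for compound 4 is therefore 45%, with a range from 33% to 57%.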

Compound 4, a percentage reported as inhibition, at one concentration (the size of the read-out at that concentration, not a potency): 40.3%
Compound 4: middle estimate off by 4.7 percentage points, on the high side; measured number inside the range.
By their numbers in this assay, from the lowest: compounds 4, 1, 2 and 3 (each within the scatter of the next).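

In this assay, for the compounds shown here, the step of a number 6.7 percentage points lower from compound 3 to compound 4 (within the scatter) is the largest so far, yet it remains unresolved, as do the step of a number 3.3 percentage points lower from compound 2 to compound 4 (within the scatter) and the step of a number 3.3 percentage points lower from compound 1 to compound 4 (within the scatter). The change from allyl to 3-methylbut-2-en-1-yl on the oxygen keeps the one double bond outside aromatic rings and adds carbon, but gives no readable difference, and the two chains with a double bond do not separate from the two saturated ones. The position has now taken four different carbon chains with no step beyond the scatter, and nothing available speaks to the reason for this.

From the compounds shown here alone, all four chains contain only carbon and hydrogen, so the effect of an amine or a carboxylic acid on the chain, or of a much longer chain or a phenyl ring in its place, remains open. Going by these compounds alone, with only the one concentration tested in this assay, it also remains open whether these four compounds would differ in potency across a full concentration series.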